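Chloro Substitution on the Bicyclic Core of Sulfonamides

The source may report more compounds than this note shows. Statements on the series, on what has been measured and on what is new or still open speak of the compounds shown alone.

Measured compounds:
Compound 1, `O=S(=O)(Nc1cccc2cc[nH]c12)c1ccc(Cl)cc1`: 7 ug/mL
Compound 2, `O=S(=O)(Nc1cc(Cl)cc2cc[nH]c12)c1ccc(Cl)cc1`: 8.5 ug/mL
Compound 3, `O=[N+]([O-])c1ccc(S(=O)(=O)Nc2cccc3cc[nH]c23)cc1`: 7.2 ug/mL

In a functional assay on MC-38 cells (Mus musculus) for antiproliferative activity, read by colorimetric assay and MTT assay (a higher number here means a weaker inhibitor, a lower number a stronger inhibitor), compound 1 gives 7 ug/mL, and compound 2 gives 8.5 ug/mL. The change chloro in place of hydrogen on an aromatic carbon produced a 1.2-fold higher number from compound 1 to compound 2 (0.08 log units; within the scatter). Compound 3 is the other measured analogue; it differs from compound 1 by nitro in place of chloro on an aromatic carbon, and that change gave a 1.0-fold higher number from compound 1 to compound 3 (0.01 log units; within the scatter).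

Compound 4, `O=[N+]([O-])c1ccc(S(=O)(=O)Nc2ccc(Cl)c3cc[nH]c23)cc1`, is not yet measured. It differs from compound 3 by chloro in place of hydrogen on an aromatic carbon. This is the same kind of change as that from compound 1 to compound 2, but not the same: in compound 4 the entering group sits ortho to a fused ring and para to a large group, whereas in compound 2 it sits meta to a large group and para to a fused ring.

Within the data shown here, the expectation for compound 4 rests on the single earlier step of a 1.2-fold higher number from compound 1 to compound 2 (0.08 log units; within the scatter). Compound 4 is accordingly estimated at 8 ug/mL, within 4 ug/mL to 16 ug/mL. This estimate means a step of a 1.1-fold higher number from compound 3 to compound 4 (0.05 log units; within the scatter), expected to stay within scatter.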

Compound 4, half-maximal inhibitory concentration: 0.67 ug/mL
Compound 4: middle estimate off by 12-fold (1.08 log units), on the high side, and the stated range ends above it.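

On the core of compound 3, chloro in place of hydrogen on an aromatic carbon gave an 11-fold lower number from compound 3 to compound 4 (1.03 log units; beyond the scatter) in this assay. The change therefore does not carry over as a fixed increment between these two cores: the same change on two cores in this assay, a 1.2-fold higher number (0.08 log units; within the scatter) from compound 1 to compound 2 and an 11-fold lower number (1.03 log units; beyond the scatter) from compound 3 to compound 4, 13-fold (1.12 log units) apart, beyond the scatter of two such steps. This does not show what separates the two steps, since they differ both in where the chloro sits (para to a large group in compound 4, meta to a large group in compound 2) and in nitro versus chloro on the other ring, with one pair on each side.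

As far as these compounds go, it remains open what chloro would do on the core of compound 1 at the place it holds in compound 4. Also open, from the compounds shown here alone, is whether a bromo, a methoxy or an amine at that place would give a step of similar size.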